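The source may report more compounds than this note shows. Statements on the series, on what has been measured and on what is new or still open speak of the compounds shown alone.

Measured to date:
compound 1 `O=C(/C(=C\c1ccc(O)cc1O)Sc1ccc(Br)cc1)c1ccc(Cl)cc1`: 50000 nM
compound 2 `O=C(/C(=C\c1ccc(O)cc1O)Sc1ccccc1Br)c1ccc(Cl)cc1`: 50000 nM
compound 3 `O=C(/C(=C\c1ccc(O)cc1O)Sc1ccccc1Br)c1ccc(Br)cc1`: 50000 nM

In a functional assay on DU-145 cells (Homo sapiens) for inhibition, read by trypan blue exclusion, with a stated time of 96 h (a lower number here means a stronger inhibitor of growth, a higher number a weaker inhibitor of growth), compound 1 gives 50000 nM, compound 2 gives 50000 nM and compound 3 gives 50000 nM. Compound 2 thus stands level with the other two at the digits recorded; the step of no change at the digits printed from compound 1 to compound 2 (within the scatter) and the step of no change at the digits printed from compound 2 to compound 3 (within the scatter) both lie within the scatter, so no change in the bromophenyl on sulfur and no exchange of the halogen on the aromatic carbon has moved the readout of this assay.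

Compound 4 `O=C(/C(=C\c1cc(Cl)cc(Cl)c1Cl)Sc1ccccc1Br)c1ccc(Cl)cc1` has not yet been tested. It differs from compound 2 in a single place: 2,3,5-trichlorophenyl in place of 2,4-dihydroxyphenyl on a double-bonded chain carbon bound to a double-bonded chain carbon. For the measured compounds named here, neither measured step touches this part of the shared core, so there is no direct precedent for it; the two steps that exist are both flat, and the series so far gives no sign of any change beyond the scatter in this assay. On that basis compound 4 is expected to sit close to compound 2, with an estimated step of no change at the digits printed from compound 2 to compound 4 (within the scatter). For compound 4 the estimate in this assay is 50000 nM, between 15000 nM and 100000 nM.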

Compound 4, concentration for 50% growth inhibition: 25000 nM
Compound 4: the middle estimate sits 2.0-fold (0.30 log units) above what was measured; low and high end bracket the measured number.
By their numbers in this assay, from the lowest: compounds 4, 1, 2 and 3 (each within the scatter of the next).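

In this assay, for the compounds shown here, the exchange of 2,4-dihydroxyphenyl for 2,3,5-trichlorophenyl on a double-bonded chain carbon gives a 2.0-fold lower number from compound 2 to compound 4 (0.30 log units; within the scatter), the first reading at this position. The entering group counts 0 hydrogen-bond donors and 0 hydrogen-bond acceptors against 2 of each for the group that leaves, yet this pair shows no step beyond the scatter, so these counts do not separate the two compounds here. No supporting measurement bears on this result.

As far as these compounds go, whether any group at this position can move the number beyond the scatter stays open, since the four compounds each lie within the scatter of the next. An amine or a carboxylic acid on this ring would test that question with groups unlike either the hydroxyls or the chlorines.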